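A Benzyloxy Group in Place of Isopentyl

This account rests on a few compounds, and the source may have more. Where it says the series, first, only, none or still open, it means among the compounds named here.

Measured in a toxicity assay on KB cells (Homo sapiens) for cytotoxicity, read by fluorescence, with a stated time of 3 days; on this read-out higher numbers stand for an effect only at larger amounts of compound and lower numbers for an effect already at smaller amounts:
Compound 1 `CCCCOC(=O)CNC(=O)[C@H](CSc1ccc([N+](=O)[O-])cc1[N+](=O)[O-])NC(=O)CC[C@H](NC(=O)c1ccccc1)C(=O)OCCCC`: > 300 uM (a limit)
Compound 2 `CCCCOC(=O)CNC(=O)[C@H](CSc1ccc([N+](=O)[O-])cc1[N+](=O)[O-])NC(=O)CC[C@H](NC(=O)OC)C(=O)OCCCC`: > 300 uM (a limit)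
Compound 3 `CCCCOC(=O)CNC(=O)[C@H](CSc1ccc([N+](=O)[O-])cc1[N+](=O)[O-])NC(=O)CC[C@H](NC(=O)CCC(C)C)C(=O)OCCCC`: 84 uM

Among these three, compound 3 alone has a true number, 84 uM. The other two compounds stand at the limit of > 300 uM in this assay, at which 2 of the 3 values shown sit. Between those two, the data show a step that the two limits leave unreadable from compound 1 to compound 2.

Compound 4 `CCCCOC(=O)CNC(=O)[C@H](CSc1ccc([N+](=O)[O-])cc1[N+](=O)[O-])NC(=O)CC[C@H](NC(=O)OCc1ccccc1)C(=O)OCCCC` differs from compound 3 in one place: benzyloxy in place of isopentyl on a carbonyl carbon. In words, benzyloxy stands in place of isopentyl on a carbonyl carbon.

Within the data shown here, two measured steps bear on this change: an at least 3.5-fold lower number from compound 1 to compound 3 (0.55 log units; beyond the scatter), and an at least 3.5-fold lower number from compound 2 to compound 3 (0.55 log units; beyond the scatter). Going by these compounds, both end at the isopentyl group, and both are limited by the assay ceiling, so their true sizes remain open. Benzyloxy holds an aromatic ring, as the phenyl of compound 1 does, and it also places an oxygen on the carbonyl carbon, as the methoxy of compound 2 does. On that resemblance alone, a modest move to a higher number is expected in this assay, and a result at the limit would be no surprise. The expected change is a 2.0-fold higher number from compound 3 to compound 4 (0.31 log units; beyond the scatter). Compound 4 is estimated at 170 uM, with an expected range of 60 uM to 450 uM.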

Compound 4, concentration for half-maximal effect: 95.2 uM
Compound 4: the middle estimate sits 1.8-fold (0.25 log units) above what was measured, within the range that was stated.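

In this assay, the change at this carbonyl carbon gives a 1.1-fold higher number from compound 3 to compound 4 (0.05 log units; within the scatter), so the two groups cannot be told apart in this assay, although only benzyloxy holds a six-membered aromatic ring. The comparison with the two compounds that each share one feature of benzyloxy gives an at least 3.1-fold lower number from compound 1 to compound 4 (0.49 log units; beyond the scatter) and an at least 3.1-fold lower number from compound 2 to compound 4 (0.49 log units; beyond the scatter), so among these four compounds neither an aromatic ring in the group nor an oxygen on the carbonyl carbon goes with the limit on its own: compound 1 and compound 2 each carry one of these and stay at the limit, while compound 4 carries both and does not. The true size of these last two steps stays unread: the limit of > 300 uM in this assay, at which 2 of the 4 values shown sit.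

Going by these compounds, it remains open whether a longer chain between the oxygen and the phenyl ring, or an amine or a carboxylic acid in place of benzyloxy on this carbonyl carbon, would leave the number where compound 3 and compound 4 stand. The compounds shown also leave open whether the same holds with a group other than butyl on the two esters of the shared core.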